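Isoxazole attachment point in the arylamine series

The compounds below may be only part of what the source reports. "The series", "measured", "known", "first", "only" and "open" are said of these compounds alone.

Compound 1 `c1coc(-c2ccccc2NCC2=NCCN2)c1` in a functional assay for activation of Alpha-1A adrenergic receptor (Homo sapiens), read by calcium flux (a higher number here means that more compound is needed for the effect, a lower number that less compound is needed), gives 0.468 nM; compound 2 `Cc1cc(-c2ccccc2NCC2=NCCN2)on1` in this assay gives 38.9 nM. Among the compounds with values here, of the two numbers so far, compound 2 holds the higher one, and the only measured step, an 83-fold higher number from compound 1 to compound 2 (1.92 log units; beyond the scatter), shows that exchanging the five-membered heteroaryl on the shared core moves the read-out strongly. Compound 3 `c1ccc(-c2cnoc2)c(NCC2=NCCN2)c1` carries the change (1,2-oxazol-4-yl in place of 3-methyl-1,2-oxazol-5-yl on an aromatic carbon). Within the data shown here, no measured step pairs two isoxazoles differing only in attachment and methyl, so the step from compound 2 to compound 3 has no direct precedent; the large size of the step from compound 1 to compound 2 only warns that this position is sensitive. A moderate change in either direction is therefore expected, set here as a 1.6-fold lower number from compound 2 to compound 3 (0.19 log units; within the scatter). Compound 3 is expected to give about 25 nM in this assay, within 3 nM to 200 nM.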

Compound 3, half-maximal effective concentration: 45.7 nM
For compound 3 the middle estimate is 1.8-fold (0.26 log units) below the measured one; measured number inside the range.
By their numbers in this assay, from the lowest: compound 1; then compounds 2 and 3 (each within the scatter of the next).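

In this assay, replacing 3-methyl-1,2-oxazol-5-yl with 1,2-oxazol-4-yl gives a 1.2-fold higher number from compound 2 to compound 3 (0.07 log units; within the scatter) and so leaves the read-out unmoved, although attachment and methyl change together. Set against furan-2-yl, 1,2-oxazol-4-yl gives a 98-fold higher number from compound 1 to compound 3 (1.99 log units; beyond the scatter), a step of similar size to an 83-fold higher number from compound 1 to compound 2 (1.92 log units; beyond the scatter), so the large gap from compound 1 holds for both 1,2-oxazoles and is not tied to one attachment or to the methyl. No measured information accounts for this gap between furan-2-yl and the two 1,2-oxazoles.

Open, as far as these compounds go, is whether attachment and methyl each matter alone and merely offset each other here, which 1,2-oxazol-5-yl without the methyl or 3-methyl-1,2-oxazol-4-yl would separate. Also open, from the compounds shown here alone, is whether thiophen-2-yl, with sulfur in place of the furan oxygen, stays close to compound 1.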